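A Longer Chain in Place of the Difluorophenyl Group

This account rests on a few compounds, and the source may have more. Where it says the series, first, only, none or still open, it means among the compounds named here.

In a functional assay on SMMC-7721 cells (Homo sapiens) for cytotoxicity, read by MTT assay, with a stated time of 72 h (a higher number here means a weaker inhibitor, a lower number a stronger inhibitor), compound 1 `O=C1C(=Cc2ccc(F)cc2)C(=O)N(c2ccc(Cl)cc2)N1c1ccc(Cl)cc1` gives 23300 nM and compound 3 `O=C1C(=Cc2ccc(F)cc2F)C(=O)N(c2ccc(Cl)cc2)N1c1ccc(Cl)cc1` gives 35800 nM, so these two stand within the scatter of each other. Compound 2 `COc1ccc(C=C2C(=O)N(c3ccc(Cl)cc3)N(c3ccc(Cl)cc3)C2=O)cc1OC` gives only a limit of the assay, > 128000 nM. Compound 4 `O=C1C(=C/C=C/c2ccccc2)C(=O)N(c2ccc(Cl)cc2)N1c1ccc(Cl)cc1` differs from compound 3 by 2-phenylethenyl in place of 2,4-difluorophenyl on a double-bonded chain carbon bound to a double-bonded ring carbon, bringing a double bond outside aromatic rings. Measured steps in this series range from a 1.5-fold higher number from compound 1 to compound 3 (0.19 log units; within the scatter) to an at least 5.4-fold higher number from compound 1 to compound 2 (0.73 log units; beyond the scatter), and an at least 3.5-fold lower number from compound 2 to compound 3 (0.55 log units; beyond the scatter). Within the data shown here, no measured compound carries 2-phenylethenyl, so the anchor is compound 3 at 35800 nM, with a wide margin. The expected step is a 1.1-fold higher number from compound 3 to compound 4 (0.05 log units; within the scatter), with no clear direction. For compound 4 the estimate is 40000 nM, with an expected range of 13000 nM to 120000 nM.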

Compound 4, half-maximal inhibitory concentration: 10100 nM
Compound 4: the middle estimate sits 4.0-fold (0.60 log units) above what was measured; the whole stated range lies above it.
By their numbers in this assay, from the lowest: compound 4; then compounds 1 and 3 (each within the scatter of the next). At a limit, above all of these: compound 2.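

In this assay, 2-phenylethenyl on this double-bonded chain carbon gives a stronger result than either fluorinated phenyl group: a 3.5-fold lower number from compound 3 to compound 4 (0.55 log units; beyond the scatter), and a 2.3-fold lower number from compound 1 to compound 4 (0.36 log units; beyond the scatter). The gap to the dimethoxy compound is wider, with an at least 12-fold lower number from compound 2 to compound 4 (1.10 log units; beyond the scatter). That step rests on a limit of the assay for compound 2, not on a number: the limit of > 128000 nM in this assay, at which 1 of the 4 values shown sits.

Compound 4 gains a double bond outside aromatic rings and loses the fluoro groups in one change, and the compounds shown do not separate the two. From the compounds shown here alone, how a longer chain or an amine would behave in this place stays open.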